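Selenium series: furan-2-yl replacing 4-methylphenyl on compound 3

The source may hold more compounds than are shown below. What is called first, only, known or untested is meant among the compounds shown, and "the series" means these compounds.

Measured compounds:
- Compound 1 `CC(C)C(Nc1ccc([Se][Se]c2ccc(NC(c3nnnn3C3CCCCC3)C(C)C)cc2)cc1)c1nnnn1C1CCCCC1`; in a functional assay on HepG2 cells (Homo sapiens) for cytotoxicity, read by MTT assay, with a stated time of 48 h (on this read-out higher numbers stand for weaker inhibition and lower numbers for stronger inhibition), compound 1 gives >= 100000 nM, which is a limit of the assay (the limit of >= 100000 nM in this assay, at which 1 of the 3 values shown sits).
- Compound 2 `CC1=C([Se]c2ccc(NCc3nnnn3C(C)(C)C)cc2)C(=O)c2ccccc2C1=O`; in this assay compound 2 gives 33000 nM.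
- Compound 3 `CC1=C([Se]c2ccc(NC(c3ccc(C)cc3)c3nnnn3C(C)(C)C)cc2)C(=O)c2ccccc2C1=O`; in this assay compound 3 gives 47000 nM.

Compound 3 holds the higher of the two numbers, its nearest neighbour being compound 2, separated by the step of a 1.4-fold higher number from compound 2 to compound 3 (0.15 log units; within the scatter), which lies within the scatter. Compound 4 `CC1=C([Se]c2ccc(NC(c3ccco3)c3nnnn3C(C)(C)C)cc2)C(=O)c2ccccc2C1=O` differs from compound 3 by furan-2-yl in place of 4-methylphenyl on a saturated chain carbon bound to an aromatic carbon and a nitrogen on an aromatic ring. Among the measured compounds shown here, the only measured step at this position is a 1.4-fold higher number from compound 2 to compound 3 (0.15 log units; within the scatter); it was within the scatter, so no step beyond the scatter is expected in this assay for compound 4 in either direction. Compound 4 is therefore estimated at 40000 nM, with a range from 15000 nM to 110000 nM. The expected step is a 1.2-fold lower number from compound 3 to compound 4 (0.07 log units; within the scatter).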

Compound 4, half-maximal inhibitory concentration: 9000 nM
Estimate against measurement, compound 4: 4.4-fold (0.65 log units) above; the measured number lies below the stated range.
By their numbers in this assay, from the lowest: compound 4; then compounds 2 and 3 (each within the scatter of the next). At a limit, above all of these: compound 1.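

In this assay, the group on this saturated chain carbon now matters: furan-2-yl gives a 5.2-fold lower number from compound 3 to compound 4 (0.72 log units; beyond the scatter) and, measured against hydrogen, a 3.7-fold lower number from compound 2 to compound 4 (0.56 log units; beyond the scatter). The earlier 4-methylphenyl step stayed within the scatter (a 1.4-fold higher number from compound 2 to compound 3 (0.15 log units; within the scatter)), so the outcome here depends on which ring enters, not merely on a ring being present. Nothing measured here accounts for the difference between the two rings.

Going by these compounds, whether the shift is specific to furan-2-yl remains open. Thiophen-2-yl or phenyl at this place would separate the ring oxygen from ring size.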